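The compounds below may be only part of what the source reports. "The series", "measured", "known", "first", "only" and "open" are said of these compounds alone.

Measured compounds:
compound 1 `C#CCSc1nc(Nc2cccc(C(F)(F)F)c2)c(C#N)c(-c2ccccc2)n1` — > 128000 nM
compound 2 `N#Cc1c(Nc2ccc(Cl)cc2)nc(SCc2cn(Cc3ccccc3Cl)nn2)nc1-c1ccccc1` — 6520 nM

Of the compounds shown here, two have been tested in a functional assay on MCF7 cells (Homo sapiens) for inhibition, read by MTT assay, with a stated time of 72 h; a higher number here means a weaker inhibitor, a lower number a stronger inhibitor. Compound 1 `C#CCSc1nc(Nc2cccc(C(F)(F)F)c2)c(C#N)c(-c2ccccc2)n1` reaches only the limit of the assay, > 128000 nM, so no number is known for it. Compound 2 `N#Cc1c(Nc2ccc(Cl)cc2)nc(SCc2cn(Cc3ccccc3Cl)nn2)nc1-c1ccccc1` gives 6520 nM in this assay. Within the data shown here, compound 2 therefore stands as the only actual number among the two results; the other value sits at the limit (the limit of > 128000 nM in this assay, at which 1 of the 2 values shown sits).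

The untested compound 3 `N#Cc1c(Nc2ccc(F)cc2)nc(SCc2cn(Cc3ccccc3Cl)nn2)nc1-c1ccccc1` differs from compound 2 in one place: fluoro in place of chloro on an aromatic carbon. Everything else in the two structures is the same, and only the halogen named there is swapped. Among the measured compounds shown here, no measured pair in this set shows what such a swap does, so there is no step to lean on. Judged only by the small size of the change, a small shift in this assay is expected, in either direction, likely not beyond the scatter of repeated measurements. For compound 3 the estimated step is a 1.4-fold higher number from compound 2 to compound 3 (0.14 log units; within the scatter). The expected value for compound 3 is 9000 nM, with a range from 3000 nM to 27000 nM.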

Compound 3, half-maximal inhibitory concentration: 19900 nM
Beside the measured number, compound 3's estimate is 2.2-fold (0.34 log units) below it, within the range that was stated.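

Among these compounds, the pair compound 2 and compound 3 gives the first direct reading of a single change in this assay, where fluoro in place of chloro on an aromatic carbon, para to a large group, gives a 3.1-fold higher number from compound 2 to compound 3 (0.48 log units; beyond the scatter). This carbon is therefore not indifferent to which halogen it carries: exchanging one heavy atom for another, with no ring, hydrogen-bond donor or acceptor involved on either side, moves the number past the usual scatter, and the 4-chlorophenyl group of compound 2 goes with the stronger inhibitor of the two. Nothing measured here bears on why the number moves in this direction.

Only these two halogens are shown at this carbon, so the reading is a single step at a single position rather than a trend. From the compounds shown here alone, how a bromo group, a methyl group, a methoxy group, an amine or a plain hydrogen at the same carbon would compare remains open, as does whether the same swap would read alike in a compound that differs elsewhere.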